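A few compounds are considered here, and "the series" means these few. Any claim that something is new, unique, unknown or untested is made for them only; others in the source may bear on it.

Working notes on the series. Compound 1 `CCc1nc(I)c2n1CCN([C@@H](C(=O)NC)c1ccccc1)C2CCc1ccc(C(F)(F)F)cc1` and compound 2 `CCc1nc(SC)c2n1CCN([C@@H](C(=O)NC)c1ccccc1)[C@H]2CCc1ccc(C(F)(F)F)cc1` share a core carrying an ethyl group, the methylamide side chain and the trifluoromethylphenyl ethyl arm, and differ on the aromatic carbon of the five-membered aromatic ring with 2 nitrogen, where compound 1 carries iodo and compound 2 carries methylthio. Among the compounds with values here, in a functional assay on CHO cells for antagonist activity at Orexin receptor type 2 (Homo sapiens), read by FLIPR and calcium flux (on this read-out lower numbers stand for stronger inhibition and higher numbers for weaker inhibition), compound 1 gives 23 nM, the higher of the two numbers so far, and in this assay compound 2 gives 14 nM; the two values lie within the scatter of each other, so no order between them can be read from these data.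

The next step goes from compound 1 to compound 3 `CCc1ncc2n1CCN([C@@H](C(=O)NC)c1ccccc1)C2CCc1ccc(C(F)(F)F)cc1`. The change is hydrogen in place of iodo on an aromatic carbon, so the position on the five-membered ring that held iodo in compound 1 is left bare. Within the data shown here, no measured pair in the set shows such a removal, so the size of the step is not known from the data. A modest weakening is expected, amounting to a 2.2-fold higher number from compound 1 to compound 3 (0.34 log units; beyond the scatter) in this assay. Compound 3 is estimated at 50 nM in this assay, with a range from 15 nM to 200 nM.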

Compound 3, half-maximal inhibitory concentration: 194 nM
Estimate against measurement, compound 3: 3.9-fold (0.59 log units) below; the range from low to high includes it.
By their numbers in this assay, from the lowest: compounds 2 and 1 (each within the scatter of the next); then compound 3.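

Replacing iodo with hydrogen on this aromatic carbon gives an 8.4-fold higher number from compound 1 to compound 3 (0.93 log units; beyond the scatter) in this assay, so the number at this position depends on what the carbon carries. Within the data shown here, the earlier pair showed only that compound 1 with iodo and compound 2 with methylthio lie within the scatter of each other; the bare position in compound 3 now places that pair on one side of a clear gap, although only the step from compound 1 is measured directly. No measurement in hand explains the size of this step.

Still open, on these data alone, is whether a small group such as fluoro or methyl at this position would keep the number close to that of compound 1 or leave it closer to that of compound 3, and whether an amine, a nitrile or a longer chain such as ethylthio would fit the same picture. The compounds shown also leave open whether the loss on removing iodo would be the same size with a longer chain than the ethyl group on the shared core.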